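This account rests on a few compounds, and the source may have more. Where it says the series, first, only, none or still open, it means among the compounds named here.

Compound 1 `C=C1CC[C@H]2[C@@](C)(CC[C@@H](OC(C)=O)[C@@]2(C)C(=O)OC)[C@@H]1CCC1=CCOC1=O`: 80600 nM
Compound 2 `C=C1CC[C@H]2[C@@](C)(CC[C@@H](OC(C)=O)[C@@]2(C)C(=O)OCc2ccccc2)[C@@H]1CCC1=CCOC1=O`: 12900 nM
Compound 3 `C=C1CC[C@H]2[C@@](C)(CC[C@@H](OC(C)=O)[C@@]2(C)C(=O)OC)[C@@H]1/C=C/C1=CCOC1=O`: 32300 nM

In a functional assay on NIH3T3 cells (Mus musculus) for inhibition, read by MTT assay, with a stated time of 72 h (on this read-out higher numbers stand for weaker inhibition and lower numbers for stronger inhibition), compound 3 at 32300 nM holds the middle place of the three numbers. Compound 1 reads higher at 80600 nM, and compound 2 reads lower at 12900 nM.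

Compound 4 `C=C1CC[C@H]2[C@@](C)(CC[C@@H](OC(C)=O)[C@@]2(C)C(=O)OCc2ccccc2)[C@@H]1/C=C/C1=CCOC1=O` has not yet been measured. It departs from compound 3 by a single change: phenyl in place of hydrogen on a saturated chain carbon bound to an oxygen next to a carbonyl group. In other words, methoxycarbonyl gives way to benzyloxycarbonyl. The same change has been measured in just one pair, a 6.2-fold lower number from compound 1 to compound 2 (0.80 log units; beyond the scatter), and this is the closest guide. Among the measured compounds shown here, the other measured step, a 2.5-fold lower number from compound 1 to compound 3 (0.40 log units; beyond the scatter), shows that the two backgrounds differ, but no measured pair shows whether the change carries over unchanged from one to the other. A step of similar or slightly smaller size toward a lower number, meaning stronger inhibition, is therefore expected in this assay. The expected step is a 5.0-fold lower number from compound 3 to compound 4 (0.70 log units; beyond the scatter). For compound 4 the estimated value is 6500 nM, with an expected range of 2500 nM to 16000 nM.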

Compound 4, half-maximal inhibitory concentration: 52700 nM
Beside the measured number, compound 4's estimate is 8.1-fold (0.91 log units) below it; measured number outside the range, above it.
By their numbers in this assay, from the lowest: compound 2; then compounds 3, 4 and 1 (each within the scatter of the next, the first and the last beyond it).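

In this assay, going from methoxycarbonyl to benzyloxycarbonyl on the core of compound 3 gives a 1.6-fold higher number from compound 3 to compound 4 (0.21 log units; within the scatter), so the clear step seen with this change on the core of compound 1 does not carry over, and its effect depends on the core: the same change on two cores in this assay, a 6.2-fold lower number (0.80 log units; beyond the scatter) from compound 1 to compound 2 and a 1.6-fold higher number (0.21 log units; within the scatter) from compound 3 to compound 4, 10-fold (1.01 log units) apart, beyond the scatter of two such steps. Read the other way, the core change that gave a lower number with methoxycarbonyl gives a 4.1-fold higher number from compound 2 to compound 4 (0.61 log units; beyond the scatter) with benzyloxycarbonyl, so the two changes do not simply add: the same change on two cores in this assay, a 2.5-fold lower number (0.40 log units; beyond the scatter) from compound 1 to compound 3 and a 4.1-fold higher number (0.61 log units; beyond the scatter) from compound 2 to compound 4, 10-fold (1.01 log units) apart, beyond the scatter of two such steps.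

The compounds shown leave open whether this dependence on the core is particular to benzyloxycarbonyl or would also appear with an ethyl ester or a free carboxylic acid at this place. They also do not tell why the two cores respond differently to the same change.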